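This account rests on a few compounds, and the source may have more. Where it says the series, first, only, none or still open, it means among the compounds named here.

Working notes on the series around the shared core of compound 1 `Cn1cccc1-c1cc(-c2cccs2)nc(N)c1C#N`. From the compounds shown here alone, compound 2 `Cn1cccc1-c1cc(-c2cccs2)[nH]c(=O)c1C#N` and compound 3 `Cn1cccc1-c1cc(-c2ccccc2)[nH]c(=O)c1C#N` are measured; compound 4 `Cn1cccc1-c1cc(-c2ccccc2)nc(N)c1C#N` is still open. Growth inhibition is read in a functional assay on MDA-MB-231 cells (Homo sapiens) for inhibition, read by sulforhodamine B assay, with a stated time of 48 h; a lower number here means a stronger inhibitor of growth, a higher number a weaker inhibitor of growth. In this assay compound 1 gives only the limit > 100000 nM. In this assay compound 2 likewise gives only the limit > 100000 nM. In this assay compound 3 gives 83200 nM. The difference between the core of compound 1 and the core of compound 2 is not broken down here.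

From compound 2 to compound 3 the change is phenyl in place of thiophen-2-yl on an aromatic carbon. The resulting step of an at least 1.2-fold lower number from compound 2 to compound 3 (0.07 log units; that floor lies within the scatter) is a floor only, set by the limit of > 100000 nM in this assay, at which 2 of the 3 values shown sit. The same kind of change separates compound 1 from compound 4: phenyl in place of thiophen-2-yl on an aromatic carbon. The two surroundings differ in wording only where the place for compound 1 to compound 4 reads meta to an amino group (1 heavy atom), while that for compound 2 to compound 3 reads meta to a group of 1 heavy atom.

Among the compounds with values here, for compound 4 the step of a number no higher from compound 1 to compound 4 (the limit leaves the size open) in this assay is expected to be of the same small order as the measured one, because compound 1 sits at the limit of > 100000 nM in this assay, at which 2 of the 3 values shown sit, and the single measured instance of the change left compound 3 near that limit. Compound 4 is accordingly estimated at 100000 nM in this assay. For compound 4 the expected range runs from 40000 nM to 300000 nM, and a limit rather than a number is the more likely report.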

Compound 4, concentration for 50% growth inhibition: 67600 nM
Estimate against measurement, compound 4: 1.5-fold (0.17 log units) above; measured number inside the range.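

In this assay, phenyl in place of thiophen-2-yl on an aromatic carbon gives an at least 1.4-fold lower number from compound 1 to compound 4 (0.17 log units; that floor lies within the scatter), so the change can now be followed on two cores, the shared core of compound 1 and the core of compound 2. Within the data shown here, this shows only that neither core gives a reading against the change carrying over, and it does not show that the change has the same size on both, or that it has any effect beyond the scatter: the same change on two cores in this assay, an at least 1.2-fold lower number (0.07 log units; that floor lies within the scatter) from compound 2 to compound 3 and an at least 1.4-fold lower number (0.17 log units; that floor lies within the scatter) from compound 1 to compound 4; the limit leaves it open whether they differ. Neither step has a size of its own, since each starts from a compound reported only as a limit, so the two can be read only as floors: the limit of > 100000 nM in this assay, at which 2 of the 4 values shown sit.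

The compounds shown leave open how the change would read from a starting compound with a measured number, for instance with a chlorine or a methoxy group on the phenyl, or with furan-2-yl in the same place. They also leave open what happens in this assay when the 1-methyl-1H-pyrrol-2-yl group gives way to another group, such as a basic amine on a longer chain or a carboxylic acid.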